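Shortening the chain between the core and the piperidine ring

The compounds below may be only part of what the source reports. "The series", "measured", "known", "first", "only" and "open" are said of these compounds alone.

Measured compounds and their values in a functional assay on HEK293 cells for agonist activity at 5-hydroxytryptamine receptor 4 (Homo sapiens), read by cAMP accumulation; on this read-out lower numbers stand for an effect already at smaller amounts and higher numbers for an effect only at larger amounts of compound:
- compound 1, `COc1cc(N)c(Cl)cc1C(=O)NCC1CCNCC1`: 398 nM
- compound 2, `COc1cc(N)c(Cl)cc1C(=O)NCCN1CCNCC1`: 501 nM
- compound 3, `CC(C)n1c(=O)n(C(=O)NCC2CCNCC2)c2ccccc21`: 15.9 nM

Compound 3 gives the lowest number of the three. Compared with compound 1 its number is lower by a margin well beyond the scatter, and compared with compound 2 by an even wider margin, so among these three compound 3 is the most potent.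

Compound 4, `CC(C)n1c(=O)n(C(=O)NC2CCNCC2)c2ccccc21`, is obtained from compound 3 by one change: piperidin-4-yl in place of (piperidin-4-yl)methyl on an amide-type nitrogen. In plain terms, the chain carbon that held the piperidine ring away from the amide-type nitrogen is taken out, and the ring is joined directly to that nitrogen.

Among the compounds with values here, only one measured step is available, and it concerns a different kind of change: a 1.3-fold higher number from compound 1 to compound 2 (0.10 log units; within the scatter). That step swapped the ring itself together with its link on a different core, and stayed within the scatter. Within the data shown here, no measured pair shows what removing a single chain carbon does. The expectation for compound 4 is therefore a modest shift in this assay, with no firm direction, though the number is expected to remain below those of compounds 1 and 2.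

Compound 4 is thus estimated at 40 nM, within a range from 8 nM to 200 nM, which means an expected step of a 2.5-fold higher number from compound 3 to compound 4 (0.40 log units; beyond the scatter).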

Compound 4, half-maximal effective concentration: 316 nM
For compound 4 the middle estimate is 7.9-fold (0.90 log units) below the measured one; the measured number lies above the stated range.
By their numbers in this assay, from the lowest: compound 3; then compounds 4, 1 and 2 (each within the scatter of the next).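

In this assay, joining the piperidine ring directly to the amide-type nitrogen, with piperidin-4-yl in place of (piperidin-4-yl)methyl, gives a large change: a 20-fold higher number from compound 3 to compound 4 (1.30 log units; beyond the scatter). Within the data shown here, this is the first measured step here that lies beyond the scatter, unlike the earlier 1.3-fold higher number from compound 1 to compound 2 (0.10 log units; within the scatter), and it shows that this position is sensitive to the removal of the chain carbon even though the piperidine ring itself remains. No measurement available here explains why this small change has so large an effect.

As far as these compounds go, it remains open whether a longer chain, such as (piperidin-4-yl)ethyl, would give a lower or a higher number than compound 3 in this assay, and so whether the chain in compound 3 is the best length or only better than no chain at all. From the compounds shown here alone, it is also open whether the same removal of the chain carbon from compound 1 would cause a step of similar size on that different core, or whether the effect belongs to the core shared by compound 3 and compound 4.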